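Methyl in place of fluoro on compound 2

This account rests on a few compounds, and the source may have more. Where it says the series, first, only, none or still open, it means among the compounds named here.

Going by the values given here, in a functional assay on RAW264.7 cells (Mus musculus) for inhibition, read by Griess assay, with stated times of 1 h and 24 h (a lower number here means a stronger inhibitor, a higher number a weaker inhibitor), compound 2 (`COc1cc(OC)c2c(c1)C(C(O)c1ccc(OCc3ccc(F)cc3)cc1)OC2=O`) gives 760 nM, the only actual number so far. Compound 1 (`COc1cc(OC)c2c(c1)C(C(O)c1ccc(OCCOc3ccccc3)cc1)OC2=O`) gives > 10000 nM, which is a limit of the assay and not a number. Among the compounds with values here, the one measured step is an at least 13-fold lower number from compound 1 to compound 2 (1.11 log units; beyond the scatter), large and beyond the scatter, and its size is only a bound, resting on (the limit of > 10000 nM in this assay, at which 1 of the 2 values shown sits). That step put 4-fluorophenyl in place of phenoxymethyl on a saturated chain carbon bound to an oxygen on an aromatic ring, so it bears only loosely on the next change.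

Compound 3 (`COc1cc(OC)c2c(c1)C(C(O)c1ccc(OCc3ccc(C)cc3)cc1)OC2=O`) differs from compound 2 at a single place: methyl in place of fluoro on an aromatic carbon. The change, para to a large group, turns 4-fluorobenzyl into 4-methylbenzyl. Within the data shown here, no measured step touches this position, so the expectation stays anchored on compound 2 at 760 nM. The expected step is a 1.2-fold higher number from compound 2 to compound 3 (0.07 log units; within the scatter), which is estimated to stay within the scatter. For compound 3 the estimated value is 900 nM, with an expected range from 300 nM to 2800 nM.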

Compound 3, half-maximal inhibitory concentration: 3120 nM
Compound 3: middle estimate off by 3.5-fold (0.54 log units), on the low side; measured number above the stated range.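

In this assay this place on the benzyl ring, para to a large group, turns out not to be indifferent: methyl in place of fluoro, one heavy atom for one with no hydrogen-bond donor or acceptor on either side, gives a 4.1-fold higher number from compound 2 to compound 3 (0.61 log units; beyond the scatter), so even this small exchange moves the number beyond the scatter. The (4-methylbenzyl)oxy side chain still keeps an edge over the longer phenoxy-ending chain, with an at least 3.2-fold lower number from compound 1 to compound 3 (0.50 log units; beyond the scatter), which shows that the gain seen with the 4-fluorobenzyl compound does not depend entirely on the fluoro. Compound 1 gives > 10000 nM, which is a limit and not a number, so the size of this last step is only a bound: the limit of > 10000 nM in this assay, at which 1 of the 3 values shown sits.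

The compounds shown do not tell what it is about fluoro and methyl that sets the size of the step between them. On these data alone, whether a hydrogen, a chloro, a methoxy or a trifluoromethyl group at the same place would read closer to compound 2 or to compound 3 also stays open.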